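Methoxy to chloro at the limit of the assay

The compounds below may be only part of what the source reports. "The series", "measured", "known", "first", "only" and "open" are said of these compounds alone.

In an ADME assay on HEK293 cells (Homo sapiens) for cytotoxicity, read by luminescence, with a stated time of 72 h (a lower number here means that less compound is needed, a higher number that more compound is needed for the effect), compound 1 `CCOC(=O)c1c(-c2cccc(-c3ccccc3)c2)[nH]c2cc(Cl)ccc2c1=O` gives > 22000 nM as a limit and not a number. Compound 2 `CCOC(=O)c1c(-c2cccc(-c3ccccc3)c2)[nH]c2cc(Cl)c(OC)cc2c1=O` gives > 22000 nM as a limit too. Compound 3 `CCOC(=O)c1c(-c2cccc(-c3ccccc3)c2)[nH]c2cc(Cl)c(Cl)cc2c1=O` carries chloro in place of methoxy on an aromatic carbon ortho to a chloro group. Among the compounds with values here, the one measured step involving methoxy is a step that the two limits leave unreadable from compound 1 to compound 2 and so offers no size to build on. The expected step of a number no higher from compound 2 to compound 3 (the limit leaves the size open) in this assay is therefore none beyond the usual scatter. Compound 3 is estimated at 22000 nM with an expected range of 9000 nM to 50000 nM and may well return only a limit again.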

Compound 3, half-maximal effective concentration: > 22000 nM
Compound 3: no number, only a limit; the forecaster's own chance of this, stated with the estimate: 75%; the middle value lies on the limit itself.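

Compound 3 gives no readable step against compound 1 or compound 2, because all three values are the same limit and not numbers: the limit of > 22000 nM in this assay, at which 3 of the 3 values shown sit.

The compounds shown leave open how far apart these three actually lie in this assay.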